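This account rests on a few compounds, and the source may have more. Where it says the series, first, only, none or still open, it means among the compounds named here.

Measured so far in a physicochemical assay for acid dissociation:
- compound 1 `COc1ccc(F)cc1CNCCCNc1ccnc2cc(Cc3ccc(C#N)cc3)ccc12`: 9.47
- compound 2 `Cc1cc(C)cc(Cc2ccc3c(NCCCNCc4ccco4)ccnc3c2)c1`: 9.47
- compound 3 `FC(F)(F)c1cc(-c2ccc3c(NCCCNCc4ccco4)ccnc3c2)cc(C(F)(F)F)c1`: 9.47

Compound 2 stands level with compound 1 and with compound 3 at the digits reported; the gap to either is within the scatter, so the three give no order among themselves. The three share the diamine linker and the fused core, and differ only in what hangs on the aromatic carbon of that core; across that variation the value does not move in this assay.

Compound 4 `c1ccc(-c2ccc3c(NCCCNCc4ccco4)ccnc3c2)cc1` has not yet been measured. Relative to compound 2 the change is phenyl in place of 3,5-dimethylbenzyl on an aromatic carbon. The group exchanged sits on the fused system, away from the amine of the linker, and the three measured compounds already vary at that same position without any shift beyond the scatter.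

No step beyond the scatter is therefore expected in this assay; the estimated step of no change at the digits printed from compound 2 to compound 4 (within the scatter) is essentially nil. Compound 4 is expected to give about 9.47, within 9.2 to 9.75.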

Compound 4, acid dissociation constant: 9.47
Beside the measured number, compound 4's estimate shows no gap at the digits printed; measured number inside the range.
By their numbers in this assay, from the lowest: compounds 1, 2, 3 and 4 (each within the scatter of the next).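

In this assay, for the compounds shown here, the exchange of phenyl for 3,5-dimethylbenzyl gives no change at the digits printed from compound 2 to compound 4 (within the scatter) and this is the first reading from a pair that differs in one place only, so this aromatic carbon is now tested with the rest of the structure held fixed. The group shrinks from 9 heavy atoms to 6 and the carbon-only six-membered aromatic ring stays, yet the read-out does not separate the two compounds. No measurement available here bears on why the value holds at this position.

From the compounds shown here alone, whether an amine or a carboxylic acid on this aromatic carbon would read the same remains open. Going by these compounds, the diamine linker is also constant throughout, so the effect of a longer chain in its place on this read-out is unknown.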